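Compound 2 to compound 4: an aromatic ring enters

The source may hold more compounds than are shown below. What is called first, only, known or untested is meant among the compounds shown, and "the series" means these compounds.

Among the measured compounds shown here, in a functional assay on DU-145 cells (Homo sapiens) for antiproliferative activity, read by sulforhodamine B assay, with a stated time of 3 days (on this read-out lower numbers stand for stronger inhibition of growth and higher numbers for weaker inhibition of growth), compound 2 `CN1CCC(C(=O)Nc2cccc(Nc3ncc(F)c(Nc4ccc(F)cc4)n3)c2)CC1` gives 1150 nM, the only actual number among the measured compounds. Compound 1 `O=C(Nc1ccc(C(F)(F)F)cc1)c1cccc(Nc2ncc(F)c(Nc3ccc(F)cc3)n2)c1` reads > 10000 nM, which is a limit of the assay. Compound 3 `CN(C)c1ccc(C(=O)Nc2cccc(Nc3ncc(F)c(Nc4ccc(F)cc4)n3)c2)cc1` reads > 10000 nM, also a limit. Compound 4 `Cn1ccnc1NC(=O)c1cccc(Nc2ncc(F)c(Nc3ccc(F)cc3)n2)c1` remains unmeasured, and it differs from compound 2 as follows: (1-methyl-1H-imidazol-2-yl)carbamoyl in place of ((1-methylpiperidin-4-yl)carbonyl)amino on an aromatic carbon. In words, (1-methyl-1H-imidazol-2-yl)carbamoyl stands in place of ((1-methylpiperidin-4-yl)carbonyl)amino on an aromatic carbon. For the measured compounds named here, the one measured step bearing on this is an at least 8.6-fold higher number from compound 2 to compound 3 (0.93 log units; beyond the scatter), with 4-(dimethylamino)phenyl in place of 1-methylpiperidin-4-yl on a carbonyl carbon. A loss of similar size is therefore expected, namely a 5.2-fold higher number from compound 2 to compound 4 (0.72 log units; beyond the scatter). Compound 4 is estimated at 6000 nM, with an expected range of 1500 nM to 20000 nM.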

Compound 4, concentration for 50% growth inhibition: 15100 nM
Beside the measured number, compound 4's estimate is 2.5-fold (0.40 log units) below it, within the range that was stated.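

In this assay, (1-methyl-1H-imidazol-2-yl)carbamoyl in place of ((1-methylpiperidin-4-yl)carbonyl)amino on this aromatic carbon gives a 13-fold higher number from compound 2 to compound 4 (1.12 log units; beyond the scatter), a loss of readable size, where the earlier step away from compound 2 ended at a limit. The step between compound 1 and compound 4 cannot be read, because compound 1 stands at a limit: the limit of > 10000 nM in this assay, at which 2 of the 4 values shown sit.

This change replaces the ring and reverses the amide together, and the compounds shown do not separate the two. On these data alone, how an amine or a carboxylic acid on this carbon would read stays open.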